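From 2-Chlorophenyl to 4-Ethoxyphenyl in an Antiproliferative Series

This account rests on a few compounds, and the source may have more. Where it says the series, first, only, none or still open, it means among the compounds named here.

Of the compounds shown here, two built on a shared core have been measured in a functional assay on FM3A cells (Mus musculus) for antiproliferative activity; on this read-out higher numbers stand for weaker inhibition and lower numbers for stronger inhibition. There, compound 1 (`COc1cc(C(=O)c2sc(-c3ccccc3Cl)cc2N)cc(OC)c1OC`) gives 34 nM, the lower of the two numbers and so the stronger inhibition. Compound 2 (`COc1cc(C(=O)c2sc(-c3cc(OC)c(OC)c(OC)c3)cc2N)cc(OC)c1OC`) gives 3500 nM, and the gap between the two lies well beyond the usual scatter.

Compound 3 (`CCOc1ccc(-c2cc(N)c(C(=O)c3cc(OC)c(OC)c(OC)c3)s2)cc1`) has not yet been measured. It departs from compound 1 in one place, on an aromatic carbon next to the ring sulfur, where 4-ethoxyphenyl stands in place of 2-chlorophenyl: 4-ethoxyphenyl in place of 2-chlorophenyl on an aromatic carbon.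

Going by the values given here, no measured pair isolates this change, so the only guide is the span from compound 1 at 34 nM to compound 2 at 3500 nM. Compound 3 is expected to fall inside that span, closer to compound 1, with moderately weaker inhibition in this assay. The expected size of the move is a 2.9-fold higher number from compound 1 to compound 3 (0.47 log units; beyond the scatter), and this estimate is uncertain. For compound 3 the estimated value is 100 nM, with an expected range from 20 nM to 600 nM.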

Compound 3, half-maximal inhibitory concentration: 510 nM
Beside the measured number, compound 3's estimate is 5.1-fold (0.71 log units) below it, within the range that was stated.
By their numbers in this assay, from the lowest: compound 1; then compound 3; then compound 2.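

In this assay, this position now has its first measured single change, on an aromatic carbon next to the ring sulfur: with 4-ethoxyphenyl in place of 2-chlorophenyl, the result is a 15-fold higher number from compound 1 to compound 3 (1.18 log units; beyond the scatter) and the step is large. The position therefore clearly distinguishes between these two aromatic groups, and compound 1 keeps the stronger inhibition of the pair, while compound 3 at 510 nM still gives a lower number than compound 2 at 3500 nM in the same assay. Nothing available explains why this exchange weakens inhibition to this extent.

The single step changes two things at once, removing the chlorine from one ring location and adding an ethoxy group at another, so the compounds shown cannot separate the contribution of each. From the compounds shown here alone, whether a plain phenyl, 4-chlorophenyl or 4-methoxyphenyl at this position would give a number closer to that of compound 1 or to that of compound 3 remains open.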